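The source may hold more compounds than are shown below. What is called first, only, known or untested is meant among the compounds shown, and "the series" means these compounds.

In a functional assay on MKN-45 cells (Homo sapiens) for inhibition, with a stated time of 72 h (on this read-out higher numbers stand for weaker inhibition and lower numbers for stronger inhibition), compound 1 (`COc1cc(C(=O)c2cccc3[nH]ccc23)cc(OC)c1OC`) gives 49.1 nM, compound 2 (`COc1cc(C(=O)c2cccc3c2ccn3C)cc(OC)c1OC`) gives 21.6 nM and compound 3 (`COc1cc(C(=O)c2ccc3c(ccn3C)c2)cc(OC)c1OC`) gives 11.2 nM. Compound 3 thus lies within the scatter of compound 2 and beyond the scatter of compound 1.

Compound 4 (`COc1cc(C(=O)c2ccc3c(ccn3CCC(=O)O)c2)cc(OC)c1OC`) carries carboxymethyl in place of hydrogen on a saturated chain carbon bound to an aromatic nitrogen of compound 3: carboxymethyl in place of hydrogen on a saturated chain carbon bound to an aromatic nitrogen.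

Within the data shown here, only one measured step bears on this, a 2.3-fold lower number from compound 1 to compound 2 (0.36 log units; beyond the scatter). It is modest, puts methyl in place of hydrogen on an aromatic nitrogen, and involves no carboxymethyl group. Among the measured compounds shown here, the series holds no measured example of this change, so the size of the next step rests on judgement and the range stays wide.

Starting from compound 3 at 11.2 nM, a clear move to a higher number, meaning weaker inhibition, is expected: a 22-fold higher number from compound 3 to compound 4 (1.35 log units; beyond the scatter). For compound 4 the expected value is 250 nM, with an estimated range from 35 nM to 2500 nM.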

Compound 4, half-maximal inhibitory concentration: > 10000 nM
Compound 4 was reported as a limit (the forecaster's own chance of this, stated with the estimate: 10%); middle value at least 40-fold (1.60 log units) away from the limit.
By their numbers in this assay, from the lowest: compounds 3 and 2 (each within the scatter of the next); then compound 1. At a limit, above all of these: compound 4.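

In this assay compound 4 gives > 10000 nM, which is a limit of the assay and not a number: the limit of > 10000 nM in this assay, at which 1 of the 4 values shown sits. The substituent on the nitrogen of this core thus decides between inhibition and none detectable within the assay's range: an at least 890-fold higher number from compound 3 to compound 4 (2.95 log units; beyond the scatter). Among these compounds, this is the first large step, and it runs in the opposite direction to the only earlier step at an aromatic nitrogen, a 2.3-fold lower number from compound 1 to compound 2 (0.36 log units; beyond the scatter), so that position does not tolerate every group placed on it.

As far as these compounds go, whether the loss follows the carboxylic acid or the length of the chain stays open. An ethyl or propyl chain without the acid, the methyl ester of the same chain, or an amine at its end would separate these two readings.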